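Stereochemical inversion in a cyclopropene nucleoside analogue

This account rests on a few compounds, and the source may have more. Where it says the series, first, only, none or still open, it means among the compounds named here.

Compound 1 `Nc1ncnc2c1ncn2/C=C1\C[C@@H]1[C@H](O)CO` — 57000 nM
Compound 2 `Nc1nc2c(ncn2/C=C2/C[C@H]2[C@@H](O)CO)c(=O)[nH]1` — 78000 nM

Two compounds were measured in an ADME assay on Akata cells (Homo sapiens) for cytotoxicity; on this read-out lower numbers stand for higher toxicity in this test and higher numbers for lower toxicity in this test. Compound 1 gives 57000 nM, the lowest of the two numbers, and compound 2 gives 78000 nM, which lies within the scatter of compound 1; neither can be called more or less toxic than the other on these data.

The step of interest leads from compound 1 to compound 3 `Nc1ncnc2c1ncn2/C=C1/C[C@H]1[C@H](O)CO`, which is not yet measured. The structural change is the two compounds have the same atoms and bonds and differ only in configuration as drawn: 2 of 3 stereo elements differ; a stereocentre at a saturated ring carbon is drawn S in compound 1 and R in compound 3; a double bond is drawn E in compound 1 and Z in compound 3. Among the measured compounds shown here, no step between measured compounds that differ in one place is available, so the size of this change in this assay has to be judged without a direct precedent. With both measured numbers sitting in the weakly toxic range, no shift beyond the scatter is expected. The estimated step of a 1.1-fold higher number from compound 1 to compound 3 (0.02 log units; within the scatter) is accordingly small. Compound 3 is expected to give about 60000 nM, in a range from 25000 nM to 150000 nM.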

Compound 3, half-maximal cytotoxic concentration: 93500 nM
Compound 3: middle estimate off by 1.6-fold (0.19 log units), on the low side, and the stated range covers the measured number.
By their numbers in this assay, from the lowest: compounds 1, 2 and 3 (each within the scatter of the next).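

In this assay, the change of the stereocentre at the saturated ring carbon from S to R, together with the double bond from E to Z, gives a 1.6-fold higher number from compound 1 to compound 3 (0.21 log units; within the scatter). Among the compounds shown here, the earlier compounds offered no step at all, whereas this pair gives a first reading of configuration alone, and on that reading the combined change does not move the number beyond the scatter. No change in atoms or bonds enters this comparison, and the reading rests on one fact: the fact that compounds 1 and 3 differ only in the configuration as drawn

From the compounds shown here alone, the two stereo elements change together in this pair, so what each contributes on its own remains open. Also open, going by these compounds, is how this read-out would respond to an amine or a carboxylic acid in place of a hydroxyl group.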